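A few compounds are considered here, and "the series" means these few. Any claim that something is new, unique, unknown or untested is made for them only; others in the source may bear on it.

Two compounds from one small series share the same core and differ only in the group placed on the aromatic ring that hangs from it. Compound 1 `Fc1ccc(-c2cn(C3CN4CCC3CC4)nn2)cc1` carries a single fluoro there; in an assay on HEK293 cells for displacement of a labelled ligand from Neuronal acetylcholine receptor; alpha4/beta2 (Homo sapiens), read by scintillation counting, with a stated time of 120 min (on this read-out lower numbers stand for stronger inhibition and higher numbers for weaker inhibition), compound 1 gives 449 nM. Compound 2 `FCCOc1cccc(-c2cn([C@H]3CN4CCC3CC4)nn2)c1` carries a 2-fluoroethoxy instead; in this assay compound 2 gives 7050 nM, the highest of the two numbers, and the gap to compound 1 lies well beyond the usual scatter.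

Compound 3 `Fc1cccc(-c2cn([C@H]3CN4CCC3CC4)nn2)c1` has not yet been measured. It differs from compound 2 by fluoro in place of 2-fluoroethoxy on an aromatic carbon. Within the data shown here, no measured pair shows exactly this exchange, so the expectation rests on the two numbers at hand. Because compound 1 with a single fluoro on that ring gives 449 nM, a downward step of roughly a 5.9-fold lower number from compound 2 to compound 3 (0.77 log units; beyond the scatter) is expected for compound 3 in this assay. Compound 3 is therefore estimated at 1200 nM, within a range of 250 nM to 5000 nM.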

Compound 3, inhibition constant: 5200 nM
Estimate against measurement, compound 3: 4.3-fold (0.64 log units) below, outside the stated range (above it).
By their numbers in this assay, from the lowest: compound 1; then compounds 3 and 2 (each within the scatter of the next).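

In this assay, fluoro in place of 2-fluoroethoxy on this aromatic carbon gives a 1.4-fold lower number from compound 2 to compound 3 (0.13 log units; within the scatter) and so leaves the two compounds indistinguishable. At this place, meta to a large group, going from 4 heavy atoms to 1 heavy atom and losing the hydrogen-bond acceptor of the chain therefore produces no change that can be read beyond the scatter. No separate measurement is available to explain this result.

As far as these compounds go, whether an amine, a carboxylic acid or a longer chain at this place would shift the number remains open. Compound 3 differs from compound 1 in more than one place, so what sets apart compound 1 at 449 nM also stays unresolved.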